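Trimming the Amide from Isopropylcarbonyl to Acetyl

The source may hold more compounds than are shown below. What is called first, only, known or untested is meant among the compounds shown, and "the series" means these compounds.

Measured compounds:
compound 1 `COc1ccc(-c2c(C)nc3c(N)cc(Cl)nn23)cc1OC` — <= 10000 nM
compound 2 `COc1ccc(-c2c(C)nn3c(NCCNC(=O)C(C)C)cc(C)nc23)cc1OC` — <= 10000 nM

Both measurements come from an assay on isolated protein for inhibition of phosphatidylinositol 4,5-bisphosphate 3-kinase catalytic subunit beta isoform (Homo sapiens); a higher number here means a weaker inhibitor, a lower number a stronger inhibitor. In this assay compound 1 gives <= 10000 nM, and that figure is a limit of the assay rather than a number. Compound 2 likewise gives <= 10000 nM in this assay, again a limit and not a number. Where compound 2 stands on the numbers shown therefore cannot be fixed more closely than the limit of <= 10000 nM in this assay, at which 2 of the 2 values shown sit, and nothing separates it from compound 1 on what has been measured.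

Compound 3 `COc1ccc(-c2c(C)nn3c(NCCNC(C)=O)cc(C)nc23)cc1OC` is the next compound to be measured. It differs from compound 2 in one place: methyl in place of isopropyl on a carbonyl carbon, so the (isopropylcarbonyl)amino group on the chain becomes an acetamido group. Among the measured compounds shown here, no step between measured compounds is available to calibrate this change. With compound 2 known only as a limit, no shift beyond the scatter is expected, and compound 3 is estimated to remain at the same limit, with a step that the limit leaves unreadable from compound 2 to compound 3 as the expected step. Compound 3 is accordingly expected to give about 9000 nM in this assay, within a range from 2000 nM to 10000 nM.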

Compound 3, half-maximal inhibitory concentration: <= 10000 nM
Compound 3 gave a limit, no number; the forecaster's own chance of this, stated with the estimate: 80%; the middle value lies beyond the limit too.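

In this assay compound 3 gives <= 10000 nM, a limit and not a number. No step from compound 2 to compound 3 can be read, and the three compounds cannot be told apart: the limit of <= 10000 nM in this assay, at which 3 of the 3 values shown sit.

The compounds shown leave open how strongly any of them inhibits in this assay, and whether methyl in place of isopropyl on the carbonyl carbon changes that at all.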